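The source may report more compounds than this note shows. Statements on the series, on what has been measured and on what is new or still open speak of the compounds shown alone.

In an ADME assay on HEK293 cells (Homo sapiens) for cytotoxicity, read by MTT assay, with a stated time of 24 h (on this read-out higher numbers stand for weaker inhibition and lower numbers for stronger inhibition), compound 1 `COC(=O)c1scc(-c2ccc(NC(=O)c3ccccn3)cc2)c1OC` is recorded as "not determined" (no result reported). Compound 2 `COC(=O)c1scc(-c2ccc(NC(=O)c3cccc(C(F)(F)F)c3)cc2)c1OC` has no single number to start from: in this assay compound 2 is likewise recorded as "not determined" (no result reported). Compound 3 `COC(=O)c1scc(-c2ccc(NC(=O)c3ccc(C(F)(F)F)cc3Br)cc2)c1OC` gives > 50000 nM, and this value is a limit of the assay, not a number. The measured evidence on the series therefore comes down to the limit of > 50000 nM in this assay, at which 1 of the 3 values shown sits.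

Compound 4 `COC(=O)c1scc(-c2ccc(NC(=O)c3ccc(C(F)(F)F)cc3)cc2)c1OC` is still to be measured. The change from compound 2 is 4-(trifluoromethyl)phenyl in place of 3-(trifluoromethyl)phenyl on a carbonyl carbon, with the same atoms joined differently. Among the measured compounds shown here, no measured pair gives a step to scale this change by, and compound 2 offers no number to step from. No shift beyond the scatter is expected in this assay, in either direction, so the expectation stays close to the only limit in hand. Compound 4 is expected to read 50000 nM, with an estimated range of 15000 nM to 100000 nM.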

Compound 4, half-maximal inhibitory concentration: 48300 nM
For compound 4 the middle estimate is 1.0-fold (0.02 log units) above the measured one; measured number inside the range.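

In this assay, among the compounds shown here, compound 4 is the first compound of the series with a single number rather than a limit. Hydrogen in place of bromo on an aromatic carbon gives an at least 1.0-fold lower number from compound 3 to compound 4 (0.01 log units; that floor lies within the scatter), so this change can be read only as a floor, and a larger step is not excluded. For compound 3 the series still holds a limit of the assay, not a number: the limit of > 50000 nM in this assay, at which 1 of the 4 values shown sits.

The step from 3-(trifluoromethyl)phenyl to 4-(trifluoromethyl)phenyl on the carbonyl carbon cannot be read, as compound 2 has no number, and the same holds for any step involving compound 1. As far as these compounds go, whether an amine in place of trifluoromethyl, or a carboxylic acid in place of the methyl ester, would move the reading beyond the scatter stays open.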